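Methyl for methoxy on compound 2

This account rests on a few compounds, and the source may have more. Where it says the series, first, only, none or still open, it means among the compounds named here.

Measured in a functional assay on HeLa cells (Homo sapiens) for antiproliferative activity, read by MTT assay (a lower number here means a stronger inhibitor, a higher number a weaker inhibitor), so far:
- compound 1 `COc1ccc(-c2ccnc(Nc3ccc([N+](=O)[O-])cc3)n2)cc1` gives 980 nM
- compound 2 `COc1ccc(-c2ccnc(Nc3ccc(Cl)cc3Cl)n2)cc1` gives 23000 nM
- compound 3 `O=[N+]([O-])c1ccc(Nc2nccc(-c3ccc(Br)cc3)n2)cc1` gives 25700 nM

Compound 2 is level with compound 3, and both numbers stand well above that of compound 1. Compound 4 `Cc1ccc(-c2ccnc(Nc3ccc(Cl)cc3Cl)n2)cc1` has methyl in place of methoxy on an aromatic carbon and is otherwise identical to compound 2.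

For the measured compounds named here, the only measured step that removes this methoxy is large: a 26-fold higher number from compound 1 to compound 3 (1.42 log units; beyond the scatter) with bromo entering. That step involves a different incoming group and a different aniline substituent pattern, so it bears only loosely. Going by the values given here, no measured step involves methyl. Compound 2 already stands at 23000 nM and compound 3 ended at 25700 nM after losing methoxy, so a repeat of that large rise is not expected. The expected change in this assay is a 1.4-fold higher number from compound 2 to compound 4 (0.14 log units; within the scatter) (a slight rise, not beyond the scatter). Compound 4 is estimated at 32000 nM (expected range 11000 nM to 90000 nM).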

Compound 4, half-maximal inhibitory concentration: 91500 nM
Estimate against measurement, compound 4: 2.9-fold (0.46 log units) below, and the stated range ends below it.
By their numbers in this assay, from the lowest: compound 1; then compounds 2 and 3 (each within the scatter of the next); then compound 4.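

In this assay, methyl in place of methoxy gives a 4.0-fold higher number from compound 2 to compound 4 (0.60 log units; beyond the scatter). Compound 2 already had a high number, yet losing the methoxy on this aromatic carbon still raised it, as with the bromo swap in a 26-fold higher number from compound 1 to compound 3 (1.42 log units; beyond the scatter); among the listed compounds, neither replacement of methoxy goes against this direction. No supporting data bear on why the number rises.

From the compounds shown here alone, it remains open whether an amine or a hydroxyl at this place would lower the number. Going by these compounds, the effect of methyl alongside the nitro-bearing aniline of compound 1 is also open.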